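The source may report more compounds than this note shows. Statements on the series, on what has been measured and on what is new or still open speak of the compounds shown alone.

Three compounds sharing a pyridinyl acrylamide... 

Of the compounds shown here, three have so far been measured in a functional assay on MCF7 cells (Homo sapiens) for inhibition, read by CCK-8 assay, with a stated time of 72 h; a higher number here means a weaker inhibitor, a lower number a stronger inhibitor: compound 1 (`O=C(/C=C/c1cccnc1)NCCCCc1ccc(S(=O)(=O)Nc2ccccc2)cc1`), compound 2 (`O=C(/C=C/c1cccnc1)NCCCc1cccc(S(=O)(=O)Nc2ccccc2)c1`) and compound 3 (`O=C(/C=C/c1cccnc1)NCCCCCCc1cccc(S(=O)(=O)Nc2ccccc2)c1`). Compound 2 gives 142 nM, compound 1 gives 5.03 nM, and compound 3 gives 0.63 nM. Compound 3 thus has the lowest number of the three, and its gaps to both others lie beyond the scatter, with compound 1 its nearest neighbour and compound 2 the furthest away. No two of these compounds differ in one place only, and all three carry the same unsubstituted phenylsulfamoyl group, so the data offer no measured precedent for a change on that phenyl.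

Compound 4 (`O=C(/C=C/c1cccnc1)NCCCCCCc1cccc(S(=O)(=O)Nc2ccc(F)cc2)c1`) departs from compound 3 by a single change, fluoro in place of hydrogen on an aromatic carbon, para to a large group, which turns phenylsulfamoyl into (4-fluorophenyl)sulfamoyl. With so small a change and nothing measured to suggest a direction, the expectation stays anchored on compound 3 at 0.63 nM. The expected outcome is a 1.1-fold higher number from compound 3 to compound 4 (0.05 log units; within the scatter), a step within the scatter in this assay. For compound 4 the estimated value is 0.7 nM, with an expected range from 0.25 nM to 2 nM.


Correction: the stray opening fragment "Three compounds sharing a pyridinyl acrylamide..." is not part of the piece; the piece begins at "Three compounds have so far been measured".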

Compound 4, half-maximal inhibitory concentration: 0.91 nM
For compound 4 the middle estimate is 1.3-fold (0.11 log units) below the measured one; the range from low to high includes it.
By their numbers in this assay, from the lowest: compounds 3 and 4 (each within the scatter of the next); then compound 1; then compound 2.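

In this assay, fluoro in place of hydrogen on an aromatic carbon, para to a large group, gives a 1.4-fold higher number from compound 3 to compound 4 (0.16 log units; within the scatter) and so leaves compound 3 and compound 4 indistinguishable in this assay. Within the data shown here, this is the first measured change on the phenyl of the phenylsulfamoyl group, which the earlier compounds all carry unsubstituted, and it shows that, at this position and against the background of compound 3, a single fluoro makes no difference that can be told from the scatter. Nothing in the data shown explains this outcome.

The compounds shown leave open whether the same position would respond in the same way to a larger substituent such as methoxy, trifluoromethyl or a carboxylic acid, or whether fluoro on another carbon of that ring would give a similar result. They also leave open whether the change from phenylsulfamoyl to (4-fluorophenyl)sulfamoyl would give a similar step on the chains of compound 1 and compound 2, or on a longer chain than that of compound 3.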